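This account rests on a few compounds, and the source may have more. Where it says the series, first, only, none or still open, it means among the compounds named here.

The measured compounds:

Compound 1, `CC[C@@H]1C(=O)N(C)c2cnc(Nc3ccc(S(=O)(=O)NC4CCCC4)cc3)nc2N1C1CCCC1`: in a functional assay on Huh-7 cells (Homo sapiens) for antiproliferative activity, read by CCK-8 assay, with a stated time of 72 h (a higher number here means a weaker inhibitor of growth, a lower number a stronger inhibitor of growth), compound 1 gives 389 nM.
Compound 2, `CC[C@@H]1C(=O)N(C)c2cnc(Nc3ccc(S(=O)(=O)NCC(C)C)cc3)nc2N1C1CCCC1`: in this assay compound 2 gives 411 nM.
Compound 3, `CC[C@@H]1C(=O)N(C)c2cnc(Nc3ccc(S(=O)(=O)NCCCO)cc3)nc2N1C1CCCC1`: in this assay compound 3 gives 262 nM.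

Compound 3 carries the lowest number of the three, but its steps from the others, a 1.5-fold lower number from compound 1 to compound 3 (0.17 log units; within the scatter) and a 1.6-fold lower number from compound 2 to compound 3 (0.20 log units; within the scatter), both lie within the scatter, as does a 1.1-fold higher number from compound 1 to compound 2 (0.02 log units; within the scatter), so the three stand level. Compound 4, `CC[C@@H]1C(=O)N(C)c2cnc(Nc3ccc(S(=O)(=O)Nc4ccccc4)cc3)nc2N1C1CCCC1`, has not been measured; it differs from compound 3 in one place: phenyl in place of 3-hydroxypropyl on a sulfonamide nitrogen. For the measured compounds named here, no measured step brings a six-membered aromatic ring of carbon only onto the sulfonamide nitrogen; the three measured steps exchanged saturated groups there and none moved the number beyond the scatter. On that basis no step beyond the scatter is expected in this assay, with the direction left open. Compound 4 is expected to give 400 nM, in a range from 150 nM to 1200 nM. The expected step is a 1.5-fold higher number from compound 3 to compound 4 (0.18 log units; within the scatter).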

Compound 4, concentration for 50% growth inhibition: 2790 nM
The estimate for compound 4 lay 7.0-fold (0.84 log units) below the measured number, outside the stated range (above it).
By their numbers in this assay, from the lowest: compounds 3, 1 and 2 (each within the scatter of the next); then compound 4.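

In this assay the sulfonamide nitrogen proves sensitive to its substituent after all: phenyl in place of 3-hydroxypropyl gives an 11-fold higher number from compound 3 to compound 4 (1.03 log units; beyond the scatter), whereas the exchanges among saturated groups had stayed within the scatter. Phenyl in place of isobutyl gives a 6.8-fold higher number from compound 2 to compound 4 (0.83 log units; beyond the scatter), and phenyl in place of cyclopentyl gives a 7.2-fold higher number from compound 1 to compound 4 (0.86 log units; beyond the scatter), so the loss appears against all three saturated groups, and since cyclopentyl stands level with the two open chains, a ring on this nitrogen does not by itself bring the loss. Nothing available explains this step.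

The compounds shown leave open whether the aromatic ring or its direct attachment to the sulfonamide nitrogen matters, which a benzyl or cyclohexyl group there would test. On these data alone, how a pyridyl ring or a substituted phenyl ring would behave at this nitrogen also remains open.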